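Cinnamamides on a naphthyl-pyridine core: amide variation

The compounds below may be only part of what the source reports. "The series", "measured", "known", "first", "only" and "open" are said of these compounds alone.

Measured so far:
compound 1 `CN1CCN(C(=O)/C=C/c2ccncc2-c2ccc3ccccc3c2)CC1`: > 10000 nM
compound 2 `Cn1ccc2cc(-c3cnccc3/C=C/C(=O)O)ccc21`: > 10000 nM

Compound 1 `CN1CCN(C(=O)/C=C/c2ccncc2-c2ccc3ccccc3c2)CC1` has been tested in a functional assay on MDA-MB-231 cells (Homo sapiens) for inhibition, read by sulforhodamine B assay, with a stated time of 72 h; a lower number here means a stronger inhibitor of growth, a higher number a weaker inhibitor of growth. In this assay compound 1 gives > 10000 nM, which is a limit of the assay and not a number. Compound 2 `Cn1ccc2cc(-c3cnccc3/C=C/C(=O)O)ccc21`, a carboxylic acid on a different core, has also been run; in this assay compound 2 gives > 10000 nM, again a limit. Compound 1 therefore stands at the limit of > 10000 nM in this assay, at which 2 of the 2 values shown sit, and no value of the series yet lies inside the measurable range.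

Compound 3 `O=C(/C=C/c1ccncc1-c1ccc2ccccc2c1)NC1CC1` is the next entry. It differs from compound 1 in one place:
cyclopropylamino in place of 4-methylpiperazin-1-yl on a carbonyl carbon
Among the compounds with values here, no step between two measured compounds is available, so the size of the change cannot be gauged from the series. With compound 1 giving > 10000 nM, nothing points in either direction, and no step beyond the usual scatter is expected in this assay. The step from compound 1 to compound 3 is expected to be a step that the limit leaves unreadable from compound 1 to compound 3. Compound 3 is expected to give about 15000 nM, within 3000 nM to 60000 nM, most likely again reported as a limit.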

Compound 3, concentration for 50% growth inhibition: 8420 nM
Compound 3: the middle estimate sits 1.8-fold (0.25 log units) above what was measured; the range from low to high includes it.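

In this assay, within the data shown here, compound 3 gives 8420 nM, the first value of the series inside the measurable range, so cyclopropylamino on this carbonyl carbon yields a readable number on the shared core. The value of compound 1, > 10000 nM, is a limit of the assay. The change of 4-methylpiperazin-1-yl to cyclopropylamino therefore gives only a floor, an at least 1.1-fold lower number from compound 1 to compound 3 (0.07 log units; that floor lies within the scatter), and that floor alone does not establish a real gain in growth inhibition, with its true size left unread: the limit of > 10000 nM in this assay, at which 2 of the 3 values shown sit.

The single change swaps the whole piperazine ring for a three-membered carbon ring and also brings in the amide hydrogen, and the compounds shown do not separate these two features. Open questions are whether a dimethylamino or morpholin-4-yl group on the same carbonyl carbon, without an amide hydrogen, would also give a value inside the range, and whether an n-butylamino chain in place of cyclopropylamino would shift the number from compound 3 by more than the usual scatter.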